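A Second Chloro Group on Two Related Cores

The source may hold more compounds than are shown below. What is called first, only, known or untested is meant among the compounds shown, and "the series" means these compounds.

Three compounds have been measured in a functional assay on T47D cells (Homo sapiens) for cytotoxicity, read by sulforhodamine B assay, with a stated time of 48 h; on this read-out higher numbers stand for weaker inhibition of growth and lower numbers for stronger inhibition of growth:
compound 1, `ClCc1cccc(Cn2cnc3ncnc(Cl)c32)c1`, gives 500 nM
compound 2, `ClCc1ccccc1Cn1cnc2ncnc(Cl)c21`, gives 4260 nM
compound 3, `ClCc1cccc(Cn2cnc3nc(Cl)nc(Cl)c32)c1`, gives 610 nM

Compound 1 and compound 2 are built from the same atoms joined differently; the difference between the two cores is not broken down here. Compound 2 gives the highest number of the three, beyond the scatter from both others. Compound 3 differs from compound 1 by chloro in place of hydrogen on an aromatic carbon, and this step gave a 1.2-fold higher number from compound 1 to compound 3 (0.09 log units; within the scatter).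

Compound 4, `ClCc1ccccc1Cn1cnc2nc(Cl)nc(Cl)c21`, differs from compound 2 by the same change: chloro in place of hydrogen on an aromatic carbon. Because compound 2 gives 4260 nM and the same change earlier gave a 1.2-fold higher number from compound 1 to compound 3 (0.09 log units; within the scatter), compound 4 is expected to stay close to compound 2. The expected step is a 1.2-fold higher number from compound 2 to compound 4 (0.07 log units; within the scatter). Compound 4 is thus estimated at 5000 nM, likely between 2000 nM and 12000 nM.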

Compound 4, concentration for total growth inhibition: 5240 nM
The estimate for compound 4 lay 1.0-fold (0.02 log units) below the measured number; low and high end bracket the measured number.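

In this assay the chloro group between two ring nitrogen atoms gave a 1.2-fold higher number from compound 2 to compound 4 (0.09 log units; within the scatter) and so made no readable difference on this core. The step matches the one on the other core: the same change on two cores in this assay, a 1.2-fold higher number (0.09 log units; within the scatter) from compound 1 to compound 3 and a 1.2-fold higher number (0.09 log units; within the scatter) from compound 2 to compound 4, 1.0-fold (0.00 log units) apart, within the scatter of two such steps. This shows that the lack of a readable effect carried over between these two cores, but since neither step lies beyond the scatter, it does not show that a change with a real effect would carry over in the same way, nor does it say anything about other cores or other assays.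

The compounds shown leave open what an amine or a methoxy group would do in this same place. They also leave open whether either group would give matching steps on both cores.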